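Compound 3 and mouse microsomal stability

The compounds below may be only part of what the source reports. "The series", "measured", "known", "first", "only" and "open" are said of these compounds alone.

Measured in an ADME assay on microsomes from liver (Mus musculus) for metabolic stability, read by mass spectrometry, with a stated time of 40 min, tested at 1 uM; a lower number here means that less of the compound is left, a higher number that more of the compound is left:
- compound 1 `COc1cc(N2CCC(C(=O)N3CCOCC3)CC2)ccc1Nc1nc(NC2CCCCC2)c2nc[nH]c2n1`: 70%
- compound 2 `COc1cc(N2CCC(CC(=O)N3CCOCC3)CC2)ccc1Nc1nc(NC2CCCCC2)c2nc[nH]c2n1`: 61%

Only these two compounds have been measured, and they lie within the scatter of each other. For the measured compounds named here, the single measured step, a number 9 percentage points lower from compound 1 to compound 2 (within the scatter), leaves compound 2 level with compound 1 on these numbers.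

The next compound is compound 3 `COc1cc(N2CCC(CC(=O)N3CCN(C)CC3)CC2)ccc1Nc1nc(NC2CCCCC2)c2nc[nH]c2n1`, which carries 4-methylpiperazin-1-yl in place of morpholin-4-yl on a carbonyl carbon.

The measured step bears on this change only indirectly. Going by the values given here, it altered the link to the carbonyl, while morpholin-4-yl stayed in both compounds, so no measured step replaces that group. The data therefore give no direct size for this change. Among the compounds with values here, with that one small step as the only guide, no shift beyond the scatter is expected in this assay, although a slightly lower number would not surprise. The expected step is a number 6 percentage points lower from compound 2 to compound 3 (within the scatter). For compound 3 the estimated value is 55%, with an expected range of 38% to 70%.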

Compound 3, percent of the compound remaining: 43%
The estimate for compound 3 lay 12 percentage points above the measured number; measured number inside the range.
By their numbers in this assay, from the lowest: compound 3; then compounds 2 and 1 (each within the scatter of the next).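

In this assay, for the compounds shown here, putting 4-methylpiperazin-1-yl in place of morpholin-4-yl on a carbonyl carbon gives a number 18 percentage points lower from compound 2 to compound 3 (beyond the scatter), so this is the first change to move the number beyond the scatter, and the amine part of the amide matters here more than the earlier change of link did. Combining both changes, the ((4-methylpiperazin-1-yl)carbonyl)methyl group in place of (morpholin-4-yl)carbonyl on a saturated ring carbon gives a number 27 percentage points lower from compound 1 to compound 3 (beyond the scatter). The change of link on its own stays within the scatter. Nothing at hand explains why this exchange of rings lowers the number.

As far as these compounds go, it remains open whether the drop follows the methyl group or the ring nitrogen that replaces the oxygen, a question that piperazin-1-yl without the methyl, or piperidin-1-yl, would address at the same carbonyl carbon. From the compounds shown here alone, it is also open whether (4-methylpiperazin-1-yl)carbonyl, carried directly on the saturated ring carbon, would show a step of the same size as the one seen with the longer link.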